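Moving the Cyclopropyl Group Around the Phenyl Ring

A few compounds are considered here, and "the series" means these few. Any claim that something is new, unique, unknown or untested is made for them only; others in the source may bear on it.

Compound 1 `COc1nc(C2=NOCC(c3ccccc3)N2)ccc1-n1cnc(C)c1`: 21 mL/min/kg
Compound 2 `COc1nc(C2=NOCC(c3ccc(C4CC4)cc3)N2)ccc1-n1cnc(C)c1`: 208 mL/min/kg

In an ADME assay on cells (Hepatocyte, Homo sapiens) for pharmacokinetics (a higher number here means faster removal of the compound, a lower number slower removal), compound 1 gives 21 mL/min/kg and compound 2 gives 208 mL/min/kg. Going by the values given here, compound 2 thus has the higher of the two numbers in this assay, and the only measured step, a 9.9-fold higher number from compound 1 to compound 2 (1.00 log units; beyond the scatter), shows that adding a cyclopropyl group to the phenyl ring raised the number considerably. Compound 3 `COc1nc(C2=NOCC(c3cccc(C4CC4)c3)N2)ccc1-n1cnc(C)c1` keeps the same atoms and differs only in 3-cyclopropylphenyl in place of 4-cyclopropylphenyl on a saturated ring carbon. Among the compounds with values here, no measured step compares two positions of the cyclopropyl group, so the step from compound 1 to compound 2 bears on it only indirectly, by showing that the cyclopropyl group itself is present in both compounds. Within the data shown here, with no comparable step to draw on, the number for compound 3 is expected to stay close to that of compound 2, with the change a 1.2-fold lower number from compound 2 to compound 3 (0.06 log units; within the scatter) likely within the scatter. The clearance of compound 3 is therefore estimated at 180 mL/min/kg, within a range of 70 mL/min/kg to 400 mL/min/kg.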

Compound 3, clearance: 29 mL/min/kg
Beside the measured number, compound 3's estimate is 6.2-fold (0.79 log units) above it; measured number below the stated range.
By their numbers in this assay, from the lowest: compounds 1 and 3 (each within the scatter of the next); then compound 2.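

In this assay, the effect of the cyclopropyl group depends on where it sits on the phenyl ring: 3-cyclopropylphenyl in place of 4-cyclopropylphenyl gives a 7.2-fold lower number from compound 2 to compound 3 (0.86 log units; beyond the scatter) on a pair of compounds with the same atoms. Set against the plain phenyl ring, adding the group as 3-cyclopropylphenyl gives a 1.4-fold higher number from compound 1 to compound 3 (0.14 log units; within the scatter), so among these compounds the high number goes with 4-cyclopropylphenyl and not with the cyclopropyl group as such. Nothing at hand explains why the two arrangements differ.

Going by these compounds, it remains open whether a different group, such as an isopropyl group or a chlorine atom, would show the same gap between these two places on the phenyl ring. On these data alone, it is also open whether the gap would hold if the shared core were changed.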